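The compounds below may be only part of what the source reports. "The series", "measured", "known", "first", "only" and "open" are said of these compounds alone.

Within the data shown here, compound 2 `CCn1cc(-c2n[nH]c3cc(-c4cc(C(=O)Nc5cccc(C(F)(F)F)c5)ccc4C)ccc23)cn1` is the stronger of the two compounds measured so far in an assay on isolated protein for inhibition of Discoidin domain-containing receptor 2 (Homo sapiens), read by ELISA, with a stated time of 60 min; a higher number here means a weaker inhibitor, a lower number a stronger inhibitor: compound 2 gives 2.6 nM, while compound 1 `Cc1ccc(C(=O)Nc2ccc(CN3CCN(C)CC3)cc2)cc1-c1ccc2cn[nH]c2c1` gives 6.7 nM in this assay, a gap beyond the usual scatter, although the two structures differ in several places and no single step links them. Compound 3 `Cc1ccc(C(=O)Nc2cccc(C(F)(F)F)c2)cc1-c1ccc2c(-c3cnn(C4CCOC4)c3)n[nH]c2c1` is the untested analogue and differs from compound 2 in one place: oxolan-3-yl in place of ethyl on an aromatic nitrogen. Among the measured compounds shown here, no measured pair isolates this change, so there is no direct precedent for the size of the step. The group that enters is larger than the one that leaves, yet the rest of the structure shared with compound 2 is untouched, and such substituent swaps at the edge of a molecule often move the number little. Compound 3 is therefore expected to show only a small step, a 1.2-fold higher number from compound 2 to compound 3 (0.09 log units; within the scatter), not beyond the scatter in either direction. Compound 3 is estimated to give 3.2 nM in this assay, in a range from 1.2 nM to 9 nM.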

Compound 3, half-maximal inhibitory concentration: 6.2 nM
For compound 3 the middle estimate is 1.9-fold (0.29 log units) below the measured one; low and high end bracket the measured number.
By their numbers in this assay, from the lowest: compound 2; then compounds 3 and 1 (each within the scatter of the next).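

Among these compounds, replacing ethyl with oxolan-3-yl on the aromatic nitrogen gives a 2.4-fold higher number from compound 2 to compound 3 (0.38 log units; beyond the scatter) in this assay and is the first measured step at this position, showing that the number responds to what sits there, though only modestly. Compound 3, with the larger group and its one five-membered non-aromatic ring and one hydrogen-bond acceptor, still gives 6.2 nM in this assay so this swap raises the number without removing inhibition. No measurement available here accounts for this rise.

Ethyl and oxolan-3-yl differ at once in size, in the ring and in the oxygen, so this single step leaves open which of these features goes with the higher number. It also leaves open how other groups on this nitrogen, such as methyl, a cyclopentyl ring without the oxygen or a longer chain ending in an amine, would compare with ethyl in this assay on the otherwise unchanged structure of compound 2.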